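The compounds below may be only part of what the source reports. "The series", "measured", "known", "first", "only" and "open" are said of these compounds alone.

Measured so far in an ADME assay on CEM-SS cells (Homo sapiens) for cytotoxicity, read by XTT assay, with a stated time of 6 days; a lower number here means that less compound is tolerated, a higher number that more compound is tolerated:
- compound 1 `CCCC(=O)OCSc1ccccc1C(=O)NCCCCCCC(N)=O` gives 10.4 uM
- compound 2 `CCCC(=O)OCSc1ccccc1C(=O)NCCCNC(C)=O` gives 21.1 uM
- compound 3 `CCCC(=O)OCSc1ccccc1C(=O)NCCCCCCNC(C)=O` gives 8 uM

Compound 2 stands highest of the three numbers, so it is the best tolerated of the set. Its nearest neighbour is compound 1, with a 2.0-fold higher number from compound 1 to compound 2 (0.31 log units; beyond the scatter); the step from compound 2 to compound 3 is a 2.6-fold lower number from compound 2 to compound 3 (0.42 log units; beyond the scatter), while a 1.3-fold lower number from compound 1 to compound 3 (0.11 log units; within the scatter).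

Compound 4 `CCCC(=O)OCSc1ccccc1C(N)=O` is not yet measured. It differs from compound 2 by hydrogen in place of 3-acetamidopropyl on an amide-type nitrogen, leaving a plain amide on the shared core.

Among the measured compounds shown here, two measured steps bear on this change, both concerning the size of the group on that amide nitrogen: a 2.6-fold lower number from compound 2 to compound 3 (0.42 log units; beyond the scatter) and a 2.0-fold higher number from compound 1 to compound 2 (0.31 log units; beyond the scatter). For the measured compounds named here, in both, the compound with the shorter side chain shows the higher number, though only three compounds support this and no measured step removes the chain entirely. Taking the chain away altogether is therefore expected to give, in this assay, either a modest rise or no step beyond the scatter: the expected step is a 1.2-fold higher number from compound 2 to compound 4 (0.09 log units; within the scatter).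

Compound 4 is thus estimated at 26 uM in this assay, with a range from 11 uM to 60 uM.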

Compound 4, half-maximal toxic concentration: 12.4 uM
Compound 4: middle estimate off by 2.1-fold (0.32 log units), on the high side, within the range that was stated.
By their numbers in this assay, from the lowest: compounds 3, 1, 4 and 2 (each within the scatter of the next, the first and the last beyond it).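

Replacing the whole 3-acetamidopropyl group on the amide-type nitrogen with hydrogen removes 7 heavy atoms, yet in this assay it gives a 1.7-fold lower number from compound 2 to compound 4 (0.23 log units; within the scatter), so this large change does not separate the two compounds beyond the usual variation between repeat measurements. The earlier compounds shown here had suggested that a shorter side chain goes with a higher number, but compound 4, with no chain at all, does not extend that trend, since its number cannot be told apart from that of compound 2. The side chain of compound 2 therefore is not required to keep the number in this assay at this level, and nothing measured here explains why the result holds once the chain is gone.

Going by these compounds, it remains open whether other groups on this nitrogen would also leave the number in this assay unchanged, for example a single methyl, or a chain carrying an amine or a carboxylic acid in place of the acetamido group. On these data alone, a longer chain also remains untested with the acetamido group held constant, so the link between chain length and tolerance still rests on very few compounds.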